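Swapping a small ring for a bromophenyl group

The source may hold more compounds than are shown below. What is called first, only, known or untested is meant among the compounds shown, and "the series" means these compounds.

Measured compounds:
- compound 1 `FC(F)(F)c1cc(NC[C@H]2CCCCN2)c2cn[nH]c2c1`: 24000 nM
- compound 2 `OC1CCCC(Nc2cccc(CNc3cc(C(F)(F)F)cc4[nH]ncc34)c2)C1`: a limit, > 100000 nM
- compound 3 `FC(F)(F)c1cc(NCC2CNC2)c2cn[nH]c2c1`: a limit, > 100000 nM

In an assay for inhibition of Indoleamine 2,3-dioxygenase 1 (Homo sapiens), with stated times of 10 min and 60 min (a lower number here means a stronger inhibitor, a higher number a weaker inhibitor), compound 1 gives 24000 nM. For compound 2 only a limit is known, > 100000 nM. For compound 3 the result is likewise only a limit, > 100000 nM, so compound 3 stands at the limit of > 100000 nM in this assay, at which 2 of the 3 values shown sit, and no number of its own is known. Compound 4 `FC(F)(F)c1cc(NCc2cccc(Br)c2)c2cn[nH]c2c1` has not yet been measured. It differs from compound 3 in one place: 3-bromophenyl in place of azetidin-3-yl on a saturated chain carbon bound to a nitrogen on an aromatic ring. Within the data shown here, no measured step involves this exchange. Among the measured compounds shown here, the one measured step, an at least 4.1-fold higher number from compound 1 to compound 3 (0.61 log units; beyond the scatter), concerns a different group at the same place and shows that what sits on this carbon can move the number by at least that amount. Since compound 3 is a limit, the direction of the coming step can be expected only loosely. Compound 4 is estimated at 40000 nM, within 6000 nM to 150000 nM. That estimate would mean an expected step of an at least 2.5-fold lower number from compound 3 to compound 4 (0.39 log units; beyond the scatter).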

Compound 4, half-maximal inhibitory concentration: > 100000 nM
Compound 4 gave a limit, no number; the forecaster's own chance of this, stated with the estimate: 40%; at least 2.5-fold (0.39 log units) between middle value and limit.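

In this assay, the 3-bromophenyl group on this saturated chain carbon yields no number of its own, and compound 4 is only a limit: the limit of > 100000 nM in this assay, at which 3 of the 4 values shown sit. Among these compounds, with 3-bromophenyl in place of piperidin-2-yl, the one readable new step is an at least 4.1-fold higher number from compound 1 to compound 4 (0.61 log units; beyond the scatter), so a second group at this place, here a six-membered aromatic ring of carbon only, also falls short of compound 1. The steps to compound 4 from compound 2 and from compound 3 cannot be read, as both ends of each are limits.

Still open, on these data alone, is whether any group on this carbon can give a lower number than compound 1 does. A cyclohexyl group would ask whether the ring nitrogen of piperidin-2-yl matters, and a longer chain ending in an amine would ask whether that ring is needed at all.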